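This account rests on a few compounds, and the source may have more. Where it says the series, first, only, none or still open, it means among the compounds named here.

Measured compounds, all in a functional assay on HBL-100 cells (Homo sapiens) for inhibition, read by sulforhodamine B assay, with a stated time of 48 h; a higher number here means a weaker inhibitor of growth, a lower number a stronger inhibitor of growth:
compound 1 `O=C(CCCCC1CCCCC1)OCC1COCCOCCOCCOCCOCCO1`
compound 2 `CC/C=C/CC(=O)OCC1COCCOCCOCCOCCOCCO1`
compound 3 `CC(=O)OCC1COCCOCCOCCOCCOCCO1`

In this assay compound 1 gives 72000 nM. Compound 2 gives > 100000 nM, which is a limit of the assay and not a number. Compound 3 gives > 100000 nM, again a limit of the assay. Compound 3 therefore stands at the limit of > 100000 nM in this assay, at which 2 of the 3 values shown sit, with only compound 1 carrying a readable number; the step of an at least 1.3-fold higher number from compound 1 to compound 3 (0.14 log units; that floor lies within the scatter), and the step that the two limits leave unreadable from compound 2 to compound 3.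

Compound 4 `O=C(CCCCc1ccccc1)OCC1COCCOCCOCCOCCOCCO1` differs from compound 3 by 3-phenylpropyl in place of hydrogen on a saturated chain carbon bound to a carbonyl carbon. Among the measured compounds shown here, the nearest measured step is the reverse of an at least 1.3-fold higher number from compound 1 to compound 3 (0.14 log units; that floor lies within the scatter), where 3-cyclohexylpropyl at the same place gave a readable number in compound 1; 3-phenylpropyl is of comparable size but carries an aromatic ring, for which no measured step exists. The expected step of an at least 1.2-fold lower number from compound 3 to compound 4 (0.09 log units; that floor lies within the scatter) is a return from the limit to a number near that of compound 1. Compound 4 is estimated at 80000 nM, within a range of 30000 nM to 200000 nM, with a fair chance that only a limit is reported.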

Compound 4, concentration for 50% growth inhibition: 69000 nM
Compound 4: the middle estimate sits 1.2-fold (0.06 log units) above what was measured; measured number inside the range.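

At this place, on a saturated chain carbon four bonds along from the carbonyl carbon, phenyl and cyclohexyl read alike in this assay with a 1.0-fold lower number from compound 1 to compound 4 (0.02 log units; within the scatter) and so an aromatic ring and a saturated ring both carry a readable number in this pair. Against the shorter groups, the steps are an at least 1.4-fold lower number from compound 3 to compound 4 (0.16 log units; that floor lies within the scatter) and an at least 1.4-fold lower number from compound 2 to compound 4 (0.16 log units; that floor lies within the scatter) and since both floors lie within the scatter, neither shows how large the gain from 3-phenylpropyl is. Compound 2 and compound 3 each remain at a limit of the assay and not a number: the limit of > 100000 nM in this assay, at which 2 of the 4 values shown sit.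

Open, on these data alone, is whether a longer chain than 4-phenylbutyl on the carbonyl carbon gives a number clearly apart from compound 1 and compound 4. Also open, as far as these compounds go, is what an amine or a carboxylic acid on the terminal ring would do.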